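Swapping a Chloromethyl for a Hydroxy on an Amide Chain

The source may report more compounds than this note shows. Statements on the series, on what has been measured and on what is new or still open speak of the compounds shown alone.

Of the compounds shown here, three built on a shared core have been tested in a functional assay on KYSE-450 cells (Homo sapiens) for inhibition, read by MTT assay, with a stated time of 48 h; a lower number here means a stronger inhibitor, a higher number a weaker inhibitor. Compound 1 `COc1ccc(CNc2cc(OC)c(OC)c(OC)c2)cc1C` gives 73800 nM in this assay. Compound 2 `COc1ccc(CN(C(=O)CCCl)c2cc(OC)c(OC)c(OC)c2)cc1O` gives 110 nM in this assay. For compound 3 `COc1cc(NCc2ccc(Br)cc2)cc(OC)c1OC`, this assay reports only a limit, > 80000 nM, and not a number; the line the limit of > 80000 nM in this assay, at which 1 of the 3 values shown sits, describes that limit. Among the two actual numbers, compound 2 holds the lowest, and the gap to compound 1 lies far beyond the usual scatter of repeated measurements, so compound 2 is clearly the stronger inhibitor of those two.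

Compound 4 `COc1ccc(CN(C(=O)CO)c2cc(OC)c(OC)c(OC)c2)cc1O` has not yet been measured. It differs from compound 2 in one place: hydroxy in place of chloromethyl on a saturated chain carbon bound to a carbonyl carbon. Within the data shown here, no measured pair in this set shows this same change, so the size of the step cannot be read off from the data and must be judged. The expectation is that the step of a 5.5-fold higher number from compound 2 to compound 4 (0.74 log units; beyond the scatter) moves toward a higher number, that is toward weaker inhibition, by more than the scatter. Compound 4 is therefore estimated at 600 nM in this assay, with a plausible range from 150 nM to 4000 nM.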

Compound 4, half-maximal inhibitory concentration: 370 nM
Compound 4: the middle estimate sits 1.6-fold (0.21 log units) above what was measured, within the range that was stated.
By their numbers in this assay, from the lowest: compound 2; then compound 4; then compound 1. At a limit, above all of these: compound 3.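

Among these compounds, this is the first pair in the set that changes the group on a saturated chain carbon bound to a carbonyl carbon, so it gives the first direct view of how this assay responds to a change there. Replacing chloromethyl with hydroxy gives a 3.4-fold higher number from compound 2 to compound 4 (0.53 log units; beyond the scatter), a modest loss that is still a real one. The chlorine is therefore not essential in this pair, since compound 4 has none and gives 370 nM, yet the swap, which can also be read as 2-chloroethyl to hydroxymethyl, does weaken inhibition and brings in a hydrogen-bond donor and acceptor that chloromethyl lacks.

As far as these compounds go, a single pair cannot separate these differences, so it remains open whether an amine, a carboxylic acid, a plain methyl or a longer chain in this place would stay near compound 2, fall near compound 4 or do something else entirely. Nothing measured for these compounds explains the size of this step, and the data give no cause for it.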